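Notes on a thiophen-2-yl variant of compound 3

A few compounds are considered here, and "the series" means these few. Any claim that something is new, unique, unknown or untested is made for them only; others in the source may bear on it.

Compound 3 `N#Cc1c(-c2ccc(Cl)cc2)nc2c(c(-c3ccccc3)nn2-c2ccccc2)c1-c1ccc(O)cc1` stands second highest of the three numbers measured in a functional assay on MV4-11 cells (Homo sapiens) for antiproliferative activity, read by resazurin assay, with a stated time of 72 h (on this read-out lower numbers stand for stronger inhibition and higher numbers for weaker inhibition), where compound 3 gives 25100 nM. Compound 1 `N#Cc1c(-c2ccc(F)cc2)nc2c(c(-c3ccccc3)nn2-c2ccccc2)c1-c1ccc(O)cc1` gives 11600 nM in this assay, and compound 2 `COc1cc(-c2c(C#N)c(-c3cccs3)nc3c2c(-c2ccccc2)nn3-c2ccccc2)ccc1O` gives 44200 nM; the gap from compound 3 to compound 2 lies within the scatter, the gap to compound 1 beyond it. Within the data shown here, the only single-point step measured so far is a 2.2-fold higher number from compound 1 to compound 3 (0.34 log units; beyond the scatter), a modest move in the weaker direction.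

Compound 4 `N#Cc1c(-c2cccs2)nc2c(c(-c3ccccc3)nn2-c2ccccc2)c1-c1ccc(O)cc1` carries thiophen-2-yl in place of 4-chlorophenyl on an aromatic carbon. Among the measured compounds shown here, no measured step covers this exchange directly. Compound 2 already holds the thiophen-2-yl group, but its hydroxyphenyl ring also carries a methoxy, so its value bears on the step only indirectly, and it sits within the scatter of compound 3. With the modest step seen for compound 1 to compound 3 and the indirect hint from compound 2, the step of a 1.3-fold higher number from compound 3 to compound 4 (0.11 log units; within the scatter) is expected to be small, if anything toward a higher number. Compound 4 is therefore expected at 32000 nM, within a range of 11000 nM to 90000 nM.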

Compound 4, half-maximal inhibitory concentration: 34200 nM
Estimate against measurement, compound 4: 1.1-fold (0.03 log units) below; the range from low to high includes it.
By their numbers in this assay, from the lowest: compound 1; then compounds 3, 4 and 2 (each within the scatter of the next).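

In this assay the exchange of 4-chlorophenyl for thiophen-2-yl, next to the ring nitrogen, gives a 1.4-fold higher number from compound 3 to compound 4 (0.13 log units; within the scatter) and so leaves the two compounds level: this position accepts the smaller five-membered ring with a sulfur atom as readily as the chlorinated six-membered ring. Among these compounds, the same exchange starting from 4-fluorophenyl gives a 2.9-fold higher number from compound 1 to compound 4 (0.47 log units; beyond the scatter) and is the only step to compound 4 that clears the scatter, so compound 1 stays apart from compound 4 while compound 3 does not. With thiophen-2-yl in place, the step for hydrogen in place of methoxy on the hydroxyphenyl ring gives a 1.3-fold lower number from compound 2 to compound 4 (0.11 log units; within the scatter) and separates neither compound from the other.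

On these data alone, whether an amine or a carboxylic acid at this position would shift the number remains open. No measured property accounts for any of these steps.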